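The compounds below may be only part of what the source reports. "The series", "measured", "known", "first", "only" and "open" are said of these compounds alone.

Compound 3, `O=S(=O)(c1cccc(F)c1)c1ccc2c(c1)CCC[C@H]2CNCCO`, stands second highest of the three numbers in an assay on isolated protein for displacement of a labelled ligand from 5-hydroxytryptamine receptor 6 (Homo sapiens) (a higher number here means a weaker inhibitor, a lower number a stronger inhibitor), where compound 3 gives 0.126 nM. Its nearest neighbour is compound 1, `O=C1CN=C(NC[C@@H]2CCCc3cc(S(=O)(=O)c4cccc(F)c4)ccc32)N1`, which in this assay gives 0.1 nM, a step of a 1.3-fold higher number from compound 1 to compound 3 (0.10 log units; within the scatter). Furthest from it is compound 2, `CN(CC(N)=O)C[C@@H]1CCCc2cc(S(=O)(=O)c3cccc(F)c3)ccc21`, which in this assay gives 1.26 nM, a step of a 10-fold lower number from compound 2 to compound 3 (1.00 log units; beyond the scatter).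

Compound 4, `COC(=O)NC[C@@H]1CCCc2cc(S(=O)(=O)c3cccc(F)c3)ccc21`, differs from compound 3 by methoxycarbonyl in place of 2-hydroxyethyl on an amine nitrogen.

Among the compounds with values here, two measured steps bear on this change. The step of a 1.3-fold higher number from compound 1 to compound 3 (0.10 log units; within the scatter) shows that the group on the amine nitrogen can be changed with little effect. The step of a 13-fold higher number from compound 1 to compound 2 (1.10 log units; beyond the scatter) and the step of a 10-fold lower number from compound 2 to compound 3 (1.00 log units; beyond the scatter) show that a change to an amide-bearing group at this place gives a markedly higher number. Since methoxycarbonyl enters at the amine nitrogen, a modest step upward in this assay is expected, of about a 12-fold higher number from compound 3 to compound 4 (1.08 log units; beyond the scatter), with compound 2 as the guide because compound 2 gives 1.26 nM. Compound 4 is therefore estimated at 1.5 nM in this assay, within a range from 0.3 nM to 8 nM.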

Compound 4, inhibition constant: 1.59 nM
For compound 4 the middle estimate is 1.1-fold (0.03 log units) below the measured one; the measured number falls inside the stated range.
By their numbers in this assay, from the lowest: compounds 1 and 3 (each within the scatter of the next); then compounds 2 and 4 (each within the scatter of the next).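

Replacing 2-hydroxyethyl with methoxycarbonyl on the amine nitrogen gives a large change in this assay, a 13-fold higher number from compound 3 to compound 4 (1.10 log units; beyond the scatter), so the small step seen earlier between compound 1 and compound 3 does not extend to every group at this place. The new group also matches the group in compound 2 within the scatter, a 1.3-fold higher number from compound 2 to compound 4 (0.10 log units; within the scatter), which shows that (methoxycarbonyl)amino and (carbamoylmethyl)(methyl)amino cannot be told apart in this assay even though they differ in make-up. With the large step of a 16-fold higher number from compound 1 to compound 4 (1.20 log units; beyond the scatter) as the widest gap in the set, the four compounds fall into two levels, compounds 1 and 3 on one side and compounds 2 and 4 on the other, and none of the four goes against this split.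

No evidence is available to explain why methoxycarbonyl and 2-hydroxyethyl differ so clearly at this nitrogen. The compounds shown leave open whether an acetyl group or a 3-hydroxypropyl chain at the same place would stand with compounds 1 and 3 or with compounds 2 and 4.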